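The compounds below may be only part of what the source reports. "The series", "measured", "known", "first", "only" and "open" are said of these compounds alone.

Compound 1, `COc1ccccc1N1CCN(C(=O)CCc2c(-c3ccccc3)[nH]c3ccc(Cl)cc23)CC1`, gives 5.6 nM. Compound 2, `COc1ccccc1N1CCN(C(=O)CCc2c(-c3ccc(Cl)cc3)[nH]c3cccc(Cl)c23)CC1`, gives 950 nM. Compound 3, `Cn1c(-c2ccc(Cl)cc2)c(CCC(=O)N2CCC(O)(Cc3ccccc3)CC2)c2cc(Br)ccc21`, gives 0.22 nM.

All three were tested in an assay on CHO cells for displacement of a labelled ligand from Substance-P receptor (Homo sapiens); a lower number here means a stronger inhibitor, a higher number a weaker inhibitor. Compound 3 has the lowest number of the three, and its gaps to compound 1 and to compound 2 both lie beyond the scatter. Compound 4, `Cn1c(-c2ccc(Cl)cc2)c(CCC(=O)N2CCC(O)(Cc3ccccc3)CC2)c2cc(-n3cccc3)ccc21`, is not yet measured; it differs from compound 3 in one place: 1H-pyrrol-1-yl in place of bromo on an aromatic carbon. Within the data shown here, no step between measured compounds is available for this change, so the expectation rests on compound 3 alone. Compound 4 is expected to remain a strong inhibitor in this assay, with at most a small shift toward a higher number, a 3.2-fold higher number from compound 3 to compound 4 (0.50 log units; beyond the scatter). Compound 4 is therefore estimated at 0.7 nM, within 0.15 nM to 4 nM.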

Compound 4, half-maximal inhibitory concentration: 2.3 nM
Compound 4: the middle estimate sits 3.3-fold (0.52 log units) below what was measured; the measured number falls inside the stated range.
By their numbers in this assay, from the lowest: compound 3; then compound 4; then compound 1; then compound 2.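

In this assay, this position now has its first measured step, a 10-fold higher number from compound 3 to compound 4 (1.02 log units; beyond the scatter), a large loss on replacing bromo with 1H-pyrrol-1-yl. The position thus responds clearly to this change, yet it accepts an added five-membered aromatic ring, and compound 4 still gives 2.3 nM as a strong inhibitor. Nothing available explains why the number rises. With only one step here, the compounds shown leave open whether the ring or the nitrogen matters. They also leave open how an amine, a methoxy or a phenyl group would read at this carbon.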